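This account rests on a few compounds, and the source may have more. Where it says the series, first, only, none or still open, it means among the compounds named here.

Within the data shown here, in an ADME assay on a cell-free system (plasma, Mus musculus) for metabolic stability, read by HPLC, with a stated time of 120 min, tested at 2 uM (a higher number here means that the compound lasts longer, a lower number that the compound disappears faster), compound 3 `Nc1nc2ccccc2n1C(=O)NCCCCc1ccccc1` gives 0.15 h, the only actual number so far. Compound 1 `COc1nc2ccccc2n1C(=O)NCCCCc1ccccc1` gives > 2 h, which is a limit. Compound 2 `O=C(NCCCCc1ccccc1)n1cnc2ccccc21` gives > 2 h, also a limit. Compound 4 `Cc1nc2ccccc2n1C(=O)NCCCCc1ccccc1` carries methyl in place of the amino of compound 3: methyl in place of amino on an aromatic carbon. Among the measured compounds shown here, two measured steps bear on this change, an at least 13-fold lower number from compound 1 to compound 3 (1.12 log units; beyond the scatter) and an at least 13-fold lower number from compound 2 to compound 3 (1.12 log units; beyond the scatter), both large and beyond the scatter, while a step that the two limits leave unreadable from compound 1 to compound 2 cannot be read. Amino thus stands alone here, and methyl is expected to behave more like methoxy and hydrogen. The estimated step in this assay is a large rise, a 17-fold higher number from compound 3 to compound 4 (1.22 log units; beyond the scatter). Compound 4 is expected at 2.5 h, with an estimated range of 0.7 h to 8 h.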

Compound 4, half-life in the plasma assay: 0.183 h
Estimate against measurement, compound 4: 14-fold (1.14 log units) above; measured number outside the range, below it.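

In a physicochemical assay for metabolic stability, read by HPLC, in phosphate buffer, at pH 7.4, tested at 10 uM (on this read-out lower numbers stand for a shorter-lived compound and higher numbers for a longer-lived compound), compound 3 gives 0.233 h and compound 4 gives 0.117 h. In the plasma assay the step is a 1.2-fold higher number from compound 3 to compound 4 (0.09 log units; within the scatter), and in the physicochemical assay it is a 2.0-fold lower number from compound 3 to compound 4 (0.30 log units; within the scatter), so methyl and amino do not separate on this aromatic carbon between two ring nitrogen atoms. In the plasma assay the steps are an at least 10-fold lower number from compound 2 to compound 4 (1.03 log units; beyond the scatter) and an at least 10-fold lower number from compound 1 to compound 4 (1.03 log units; beyond the scatter), which place methyl with amino, apart from hydrogen and methoxy, so the short half-life is not peculiar to amino. Both of these steps give only a minimum size: the limit of > 2 h in the plasma assay, at which 2 of the 4 values shown sit.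

As far as these compounds go, whether ethyl or hydroxyl at this position would follow methyl or methoxy stays open. The step between compound 1 and compound 2 cannot be read.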